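Replacing a chlorophenyl sulfone with a thiophene sulfone

A few compounds are considered here, and "the series" means these few. Any claim that something is new, unique, unknown or untested is made for them only; others in the source may bear on it.

The measured compounds:
compound 1 `CCCn1nc(S(=O)(=O)c2cccc3ccccc23)c2cc(N3CCNCC3)ccc21`, 2.2 nM
compound 2 `CN1CCN(c2ccc3[nH]nc(S(=O)(=O)c4ccc(Cl)cc4)c3c2)CC1`, 8.1 nM
compound 3 `O=S(=O)(c1ccc(Cl)cc1)c1n[nH]c2cc(N3CCNCC3)ccc12`, 110 nM

Of the compounds shown here, three have been tested in an assay on HeLa cells for displacement of a labelled ligand from 5-hydroxytryptamine receptor 6 (Homo sapiens); a lower number here means a stronger inhibitor, a higher number a weaker inhibitor. Compound 2 gives 8.1 nM, the second highest of the three numbers. Its nearest neighbour in value is compound 1, which gives the lower number 2.2 nM, a gap beyond the usual scatter. Its furthest neighbour is compound 3, which gives the higher number 110 nM, a gap also well beyond the scatter. None of these three pairs differs in a single place, so the numbers alone are what is known.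

Compound 4 `CN1CCN(c2ccc3[nH]nc(S(=O)(=O)c4cccs4)c3c2)CC1` has not yet been measured. It differs from compound 2 in one place: thiophen-2-yl in place of 4-chlorophenyl on a sulfonyl sulfur. The sulfonyl sulfur keeps its aromatic carbon neighbour on the other side, and the rest of the shared core is unchanged.

Among the compounds with values here, no step between measured compounds tells how this swap behaves. A small step is expected in this assay, most likely toward a slightly higher number, or none beyond the scatter. The expected change is a 1.5-fold higher number from compound 2 to compound 4 (0.17 log units; within the scatter). Compound 4 is therefore estimated at 12 nM, within a range from 4 nM to 40 nM.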

Compound 4, inhibition constant: 7.8 nM
Beside the measured number, compound 4's estimate is 1.5-fold (0.19 log units) above it, within the range that was stated.
By their numbers in this assay, from the lowest: compound 1; then compounds 4 and 2 (each within the scatter of the next); then compound 3.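

In this assay, within the data shown here, thiophen-2-yl in place of 4-chlorophenyl on a sulfonyl sulfur gives a 1.0-fold lower number from compound 2 to compound 4 (0.02 log units; within the scatter), the first step here that isolates a single place in the structure. It shows that, in this pair, this position accepts a five-membered aromatic ring with one hetero atom in place of a six-membered carbon ring bearing chlorine, with no difference beyond the scatter, even though the entering group has fewer heavy atoms and no chlorine. Nothing available explains why the two groups read alike in this pair.

This single step cannot say whether the same swap would read alike on compound 3, or on the differently substituted core of compound 1, so it stands for this pair alone. Also open, on these data alone, is how the sulfonyl sulfur would fare with a group that has no aromatic ring at all, such as an ethyl chain, or with an aromatic ring that carries an amine or a carboxylic acid.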